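Inserting a carbamoylamino link while keeping the fluorophenyl

The source may hold more compounds than are shown below. What is called first, only, known or untested is meant among the compounds shown, and "the series" means these compounds.

Compound 1 `COc1cc(NC(C)CCCNC(=O)Nc2ccc(F)cc2)c2ncccc2c1` is the more potent of the two measured compounds: in a functional assay on CCRF-CEM cells (Homo sapiens) for inhibition, read by MTT assay, with a stated time of 72 h (on this read-out higher numbers stand for weaker inhibition and lower numbers for stronger inhibition), compound 1 gives 26000 nM, the lowest of the two numbers available. Its nearest neighbour is compound 2 `COc1cc(NC(C)CCCNC(=O)NNC(=O)Nc2ccc(O)cc2)c2ncccc2c1`, which in this assay gives 111000 nM; the change between them is a 4.3-fold higher number from compound 1 to compound 2 (0.63 log units; beyond the scatter). Compound 3 `COc1cc(NC(C)CCCNC(=O)NNC(=O)Nc2ccc(F)cc2)c2ncccc2c1` has not been measured. It differs from compound 1 in one place: ((4-fluorophenyl)carbamoyl)amino in place of 4-fluorophenyl on an amide-type nitrogen. Going by the values given here, the only measured step that bears on this change is the one from compound 1 to compound 2, where the same kind of insertion, though ending in a hydroxyphenyl rather than a fluorophenyl, weakened inhibition modestly. A step of similar direction but somewhat smaller size is therefore expected for compound 3, namely a 2.7-fold higher number from compound 1 to compound 3 (0.43 log units; beyond the scatter). Compound 3 is estimated at 70000 nM in this assay, with a likely range from 30000 nM to 160000 nM.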

Compound 3, half-maximal inhibitory concentration: 118000 nM
The estimate for compound 3 lay 1.7-fold (0.23 log units) below the measured number; the range from low to high includes it.
By their numbers in this assay, from the lowest: compound 1; then compounds 2 and 3 (each within the scatter of the next).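

With the fluorophenyl kept, ((4-fluorophenyl)carbamoyl)amino in place of 4-fluorophenyl on the amide-type nitrogen gives, in this assay, a 4.5-fold higher number from compound 1 to compound 3 (0.66 log units; beyond the scatter), so the weakening seen earlier with a hydroxyphenyl end also appears with a fluorophenyl end. Fluoro in place of hydroxy on the aromatic carbon gives a 1.1-fold higher number from compound 2 to compound 3 (0.03 log units; within the scatter), so this read-out does not tell these two end groups apart once the link is inserted. No measurement offered here accounts for the weakening.

From the compounds shown here alone, it remains open whether an amine or a carboxylic acid in place of the fluoro on that aromatic carbon would also leave the number unchanged. Also open, going by these compounds, is whether a simple amino link, without the added carbonyl, would give a step of similar size.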